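This account rests on a few compounds, and the source may have more. Where it says the series, first, only, none or still open, it means among the compounds named here.

Working notes on the series. In a functional assay on MV4-11 cells (Homo sapiens) for inhibition, read by luminescence, with a stated time of 72 h (a lower number here means a stronger inhibitor, a higher number a weaker inhibitor), compound 1 (`CCN1CCN(Cc2cc(Nc3ncc(F)c(-c4ccc(F)cc4OC)n3)cc3c2OCC(=O)N3CC)CC1`) gives 142 nM, compound 2 (`CCN1C(=O)COc2c(CN3CCN(C(C)C)CC3)cc(Nc3ncc(F)c(-c4ccc(F)cc4OC)n3)cc21`) gives 149 nM and compound 3 (`CCN1C(=O)COc2c(CN3CCC(N(C)C)C3)cc(Nc3ncc(F)c(-c4ccc(F)cc4OC)n3)cc21`) gives 124 nM. Compound 3 therefore stands level with the other two, all three values lying within the scatter of each other.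

The step under review leads to compound 4 (`CCN1C(=O)COc2c(CN3CCN(C4COC4)CC3)cc(Nc3ncc(F)c(-c4ccc(F)cc4OC)n3)cc21`), with 4-(oxetan-3-yl)piperazin-1-yl in place of 3-(dimethylamino)pyrrolidin-1-yl on a saturated chain carbon bound to an aromatic carbon.

Among the measured compounds shown here, three measured steps bear on this change. Replacing 4-ethylpiperazin-1-yl with 3-(dimethylamino)pyrrolidin-1-yl gives a 1.1-fold lower number from compound 1 to compound 3 (0.06 log units; within the scatter), and replacing 4-isopropylpiperazin-1-yl with the same group gives a 1.2-fold lower number from compound 2 to compound 3 (0.08 log units; within the scatter). Within the piperazine pair, the change of the substituent gives a 1.0-fold higher number from compound 1 to compound 2 (0.02 log units; within the scatter). All three are small, so no step beyond the scatter is expected in this assay, and no direction can be assigned with confidence. For the measured compounds named here, no measured compound carries the oxetan-3-yl group, so the data offer no direct reading of it, and the range is kept wide.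

The expected step is a 1.3-fold higher number from compound 3 to compound 4 (0.11 log units; within the scatter). For compound 4 the estimated value is 160 nM, with an expected range from 75 nM to 340 nM.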

Compound 4, half-maximal inhibitory concentration: 105 nM
Compound 4: the middle estimate sits 1.5-fold (0.18 log units) above what was measured; the measured number falls inside the stated range.
By their numbers in this assay, from the lowest: compounds 4, 3, 1 and 2 (each within the scatter of the next).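

In this assay, the four-membered ring enters this position without a step beyond the scatter: 4-(oxetan-3-yl)piperazin-1-yl in place of 3-(dimethylamino)pyrrolidin-1-yl gives a 1.2-fold lower number from compound 3 to compound 4 (0.07 log units; within the scatter) and so extends the level reading to a group with one more oxygen and a second ring. Among the compounds shown here, the new compound also gives the first direct reading on the amine nitrogen in a ring, where oxetan-3-yl in place of isopropyl gives a 1.4-fold lower number from compound 2 to compound 4 (0.15 log units; within the scatter) and oxetan-3-yl in place of ethyl gives a 1.4-fold lower number from compound 1 to compound 4 (0.13 log units; within the scatter) and all of these steps remain within the scatter, so the ethyl, isopropyl and oxetan-3-yl groups cannot be told apart here. No measurement on hand accounts for this level reading.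

The compounds shown leave open whether any substituent on that ring nitrogen moves the number beyond the scatter, for instance an acetyl group, a carboxylic acid or a longer chain ending in a hydroxyl. They also leave open whether a morpholine on the saturated chain carbon, with no second amine nitrogen, would stay level with these four compounds.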